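Series notes: step from compound 3 to compound 4

The compounds below may be only part of what the source reports. "The series", "measured", "known", "first", "only" and "open" are said of these compounds alone.

Three compounds of the shared core carry a number in a physicochemical assay for lipophilicity; a higher number here means a more lipophilic compound, a lower number a more polar compound. Compound 1 `CN(CCCN1CCCCC1)c1ccc(C(=O)N2CCc3ccc(OS(N)(=O)=O)cc3C2)cc1` gives 1.93 and compound 2 `CN(C)CCCN(Cc1ccccc1)c1ccc(C(=O)N2CCc3ccc(OS(N)(=O)=O)cc3C2)cc1` gives 1.93, two values within the scatter of each other. Compound 3 `CCN(Cc1ccccc1)c1ccc(C(=O)N2CCc3ccc(OS(N)(=O)=O)cc3C2)cc1` gives 3.08, the highest of the three. The two steps known so far both end at compound 3: a number 1.15 log units higher from compound 1 to compound 3 (beyond the scatter) and a number 1.15 log units higher from compound 2 to compound 3 (beyond the scatter), each of them large and beyond the scatter.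

Compound 4 `NS(=O)(=O)Oc1ccc2c(c1)CN(C(=O)c1ccc(N(Cc3ccccc3)Cc3ccco3)cc1)CC2` differs from compound 3 in one place: furan-2-yl in place of methyl on a saturated chain carbon bound to a nitrogen on an aromatic ring. Neither measured step bears on this change directly; both replaced or removed a chain carrying a second nitrogen, whereas here a methyl on the ethyl is exchanged for a five-membered aromatic ring carrying one acceptor. Going by the values given here, no measured pair shows what such an exchange does in this assay, so the expectation rests on the counted difference alone: more heavy atoms enter than leave, and an upward step is expected.

For compound 4 the estimate in this assay is 3.8, with a range from 3.2 to 4.4, meaning an expected step of a number 0.72 log units higher from compound 3 to compound 4 (beyond the scatter), beyond the scatter.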

Compound 4, partition coefficient: 1.93
The estimate for compound 4 lay 1.87 log units above the measured number; the measured number lies below the stated range.
By their numbers in this assay, from the lowest: compounds 1, 2 and 4 (each within the scatter of the next); then compound 3.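

At the saturated chain carbon bound to a nitrogen on an aromatic ring, furan-2-yl in place of methyl gives a number 1.15 log units lower from compound 3 to compound 4 (beyond the scatter) in this assay, so at this position a rise in the heavy-atom count goes with a fall in the number. The same place also takes furan-2-yl in place of 2-(dimethylamino)ethyl with no change at the digits printed from compound 2 to compound 4 (within the scatter), which means that the low number of compound 2 is matched by a group with a ring and one hydrogen-bond acceptor and no second nitrogen, and that a low number at this place is not tied to a chain ending in an amine. Nothing at hand accounts for either step.

The compounds shown leave open whether the step from methyl belongs to the furan-2-yl ring as a whole or to its oxygen, a question that phenyl or thiophen-2-yl at the same place would separate. They also leave open how the number runs with plain chains here, as with propyl or butyl in place of methyl, and whether the step to furan-2-yl would hold on another core.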